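From chloro to trifluoromethyl on compound 2

The source may hold more compounds than are shown below. What is called first, only, known or untested is meant among the compounds shown, and "the series" means these compounds.

Compound 1 `O=C(/C=C\Nc1ccc(F)cc1)c1cn(-c2ccccc2)nc1-c1ccccc1` and compound 2 `O=C(/C=C\Nc1ccc(Cl)cc1)c1cn(-c2ccccc2)nc1-c1ccccc1` share one core and differ in a single group on an aromatic carbon. In a functional assay on A549 cells (Homo sapiens) for antiproliferative activity, read by MTT assay, with a stated time of 48 h (a lower number here means a stronger inhibitor, a higher number a weaker inhibitor), compound 1 gives 4670 nM, and compound 2 gives 14100 nM. The step of a 3.0-fold higher number from compound 1 to compound 2 (0.48 log units; beyond the scatter) is the only one measured so far, and it leaves compound 2 with the higher of the two numbers. Compound 3 `O=C(/C=C\Nc1ccc(C(F)(F)F)cc1)c1cn(-c2ccccc2)nc1-c1ccccc1` carries the change (trifluoromethyl in place of chloro on an aromatic carbon). Among the measured compounds shown here, the one measured step, a 3.0-fold higher number from compound 1 to compound 2 (0.48 log units; beyond the scatter), bears on this only loosely: it ran toward a weaker inhibitor when the group at this carbon changed, but no step to trifluoromethyl has been measured. A further small rise, or no step beyond the scatter, is the expectation in this assay. Compound 3 is therefore estimated at 18000 nM, within 6000 nM to 50000 nM, which is an expected step of a 1.3-fold higher number from compound 2 to compound 3 (0.11 log units; within the scatter).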

Compound 3, half-maximal inhibitory concentration: > 50000 nM
Compound 3: a limit, no number; the forecaster's own chance of this, stated with the estimate: 20%; at least 2.7-fold (0.44 log units) between middle value and limit.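

In this assay compound 3 gives a limit of the assay and not a number: the limit of > 50000 nM in this assay, at which 1 of the 3 values shown sits.
Even so, the change of chloro to trifluoromethyl can be read as an at least 3.5-fold higher number from compound 2 to compound 3 (0.54 log units; beyond the scatter), and the change of fluoro to trifluoromethyl as an at least 10-fold higher number from compound 1 to compound 3 (1.02 log units; beyond the scatter).
The earlier pair offered a single modest step at this aromatic carbon, whereas the three compounds now show a large span, rising in the order fluoro, chloro, trifluoromethyl, with none of the three going against that order.

How far compound 3 lies past its limit cannot be read from these data. Also open, going by these compounds, is whether an amine, a hydroxyl or a carboxylic acid at this carbon would give a number lower than that of compound 1, and how changes elsewhere on the shared core would behave.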